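A few compounds are considered here, and "the series" means these few. Any claim that something is new, unique, unknown or untested is made for them only; others in the source may bear on it.

Measured compounds:
Compound 1, `COc1cc(C)cc(-c2c(-c3ccnc(-c4ccc(C(C)=O)cc4)c3)cnn2CC#N)c1`: 94%
Compound 2, `COc1cc(C)cc(-c2nn(CC#N)cc2-c2ccc(-c3cccc(C(C)=O)c3)nc2)c1`: 92%
Compound 3, `Cc1cc(O)cc(-c2nn(CC#N)cc2-c2ccnc(-c3ccc(Oc4ccccc4)cc3)c2)c1`: 94%

All three measured compounds share the same core and the same nitrile-bearing side chain, and all three leave nearly the whole cell population in place at the single concentration tested. In a functional assay on SN12C cells (Homo sapiens) for cytotoxicity, read by sulforhodamine B assay, with a stated time of 48 h, tested at 0.001 uM (a higher number here means a weaker effect of the compound at the concentration tested, a lower number a stronger effect), compound 3 gives 94%, which stands level with compound 1 at the digits shown, and compound 2, with 92%, lies within the scatter of both. For the measured compounds named here, no pair among the three differs in one place only, so no single structural step can be tied to a change in the read-out; the three numbers simply sit together.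

Compound 4, `Cc1cc(O)cc(-c2nn(CC#N)cc2-c2ccnc(-c3ccc(N(C)C)cc3)c2)c1`, is not yet measured. It departs from compound 3 by dimethylamino in place of phenoxy on an aromatic carbon. Nothing in the measured set shows what such an exchange does in this assay, and the three numbers already gathered move hardly at all across larger changes elsewhere on the molecule. The step of a number 1 percentage points lower from compound 3 to compound 4 (within the scatter) is therefore expected to be none beyond the scatter. Compound 4 is estimated to give 93% in this assay, with a range from 84% to 100%.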

Compound 4, a percentage reported as activity, at one concentration (the size of the read-out at that concentration, not a potency): 97%
Compound 4: the middle estimate sits 4 percentage points below what was measured; low and high end bracket the measured number.
By their numbers in this assay, from the lowest: compounds 2, 1, 3 and 4 (each within the scatter of the next).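

In this assay, for the compounds shown here, replacing phenoxy with dimethylamino on an aromatic carbon, para to a large group, gives a number 3 percentage points higher from compound 3 to compound 4 (within the scatter), and this is the first step in the set that can be tied to one place on the molecule. It shows that, at this position and this single low concentration, a group with no ring and fewer heavy atoms gives a read-out within the scatter of the six-membered aromatic ring it replaces, so neither that ring nor the oxygen of phenoxy is shown to matter to this read-out. Nothing available explains this result, and no measurement of any property of the two groups bears on it.

On these data alone, whether a different group on the same aromatic carbon, such as a carboxylic acid, a primary amine or a longer chain ending in morpholine, would give a step beyond the scatter remains open. Also open, as far as these compounds go, is whether phenoxy and dimethylamino would still give matching read-outs at a higher concentration, where the cells might respond more strongly to the compounds.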